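This account rests on a few compounds, and the source may have more. Where it says the series, first, only, none or still open, it means among the compounds named here.

Working notes on the ester chain of the series.

Two compounds are measured. Compound 1 `CCCCCCCCOC(=O)CCC(=O)N1CCN(CCCOc2cc3c(Nc4ccc(F)c(Cl)c4)ncnc3cc2OC)CC1` in a functional assay on A549 cells (Homo sapiens) for cytotoxicity, read by MTT assay, with a stated time of 24 h, tested at 20 uM (on this read-out higher numbers stand for a weaker effect at the one concentration tested and lower numbers for a stronger effect), gives 80%. Compound 2 `CCCCCCCCCOC(=O)CCC(=O)N1CCN(CCCOc2cc3c(Nc4ccc(F)c(Cl)c4)ncnc3cc2OC)CC1` in this assay gives 79.7%. Going by the values given here, the only measured step is a number 0.3 percentage points lower from compound 1 to compound 2 (within the scatter), so the two numbers do not separate. On the numbers shown compound 2 sits at the bottom of the pair, with compound 1 its single neighbour, and the gap to compound 1 is within the scatter, so no real difference between them is established.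

Compound 3 `CCCCCCCCCCCCCOC(=O)CCC(=O)N1CCN(CCCOc2cc3c(Nc4ccc(F)c(Cl)c4)ncnc3cc2OC)CC1` is the next member, not yet measured. It differs from compound 2 by butyl in place of hydrogen on a saturated chain carbon, nine bonds along the chain from an oxygen next to a carbonyl group. Among the compounds with values here, the one step that bears on this is a number 0.3 percentage points lower from compound 1 to compound 2 (within the scatter), which lengthened the same saturated chain and moved the read-out by nothing beyond the scatter. Within the data shown here, only one such step is known, and it is a smaller extension than the one now made, so the basis is thin. The expected step in this assay is a number 0.7 percentage points lower from compound 2 to compound 3 (within the scatter), that is, none beyond the scatter. Compound 3 is therefore estimated at 79%, with a range from 66% to 92%.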

Compound 3, a percentage reported as activity, at one concentration (the size of the read-out at that concentration, not a potency): 93.8%
The estimate for compound 3 lay 14.8 percentage points below the measured number; measured number above the stated range.
By their numbers in this assay, from the lowest: compounds 2 and 1 (each within the scatter of the next); then compound 3.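

In this assay, butyl in place of hydrogen on a saturated chain carbon, nine bonds along the chain from an oxygen next to a carbonyl group, gives a number 14.1 percentage points higher from compound 2 to compound 3 (beyond the scatter), so this end of the ester chain is not indifferent to length, and the shift is towards a weaker effect at the one concentration tested. The larger extension gives a number 13.8 percentage points higher from compound 1 to compound 3 (beyond the scatter), which points the same way, whereas the methyl extension gave only a number 0.3 percentage points lower from compound 1 to compound 2 (within the scatter), so a small extension and a larger one at this end do not behave alike. No measurement at hand accounts for this difference.

Going by these compounds alone, with only three chain lengths, it remains open whether the read-out climbs gradually or in one jump between compound 2 and compound 3, and a decyl or undecyl ester would bear directly on that. Also open, going by these compounds, is how a still longer chain, or a chain ending in an amine or a carboxylic acid, would read in this assay.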